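Swapping a nitro for a fluoro in compound 4

The compounds below may be only part of what the source reports. "The series", "measured", "known", "first", "only" and "open" are said of these compounds alone.

Measured in a functional assay on CCRF-CEM cells (Homo sapiens) for cytotoxicity, in the presence of a further agent that is not named here; on this read-out higher numbers stand for weaker inhibition and lower numbers for stronger inhibition:
- compound 1 `COC(=O)c1ccc(CN(CCCc2c(N)nc(N)nc2O)c2cc(F)cc(F)c2[N+](=O)[O-])cc1`: > 100000 nM (a limit of the assay)
- compound 2 `Nc1nc(N)c(CCCN(Cc2ccc(NC(CCC(=O)O)C(=O)O)cc2)c2cc(F)c([N+](=O)[O-])cc2[N+](=O)[O-])c(O)n1`: 43000 nM
- compound 3 `COC(=O)c1ccc(CN(CCCc2c(N)nc(N)nc2O)c2cc(F)c([N+](=O)[O-])cc2[N+](=O)[O-])cc1`: 3500 nM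

For the measured compounds named here, compound 3 holds the lowest of the two true numbers, and the only measured step is a 12-fold lower number from compound 2 to compound 3 (1.09 log units; beyond the scatter). Compound 4 `COC(=O)c1ccc(CN(CCCc2c(N)nc(N)nc2O)c2cc(F)c(F)cc2[N+](=O)[O-])cc1` departs from compound 3 by fluoro in place of nitro on an aromatic carbon. The measured step changes a different part of the molecule, so it gives no direct size for this swap. Like compound 4, compound 1 has only one nitro group, and its > 100000 nM is a limit. A move towards weaker inhibition in this assay is therefore expected, and the estimated change is a 7.1-fold higher number from compound 3 to compound 4 (0.85 log units; beyond the scatter). For compound 4 the expected value is 25000 nM, with an estimated range from 7000 nM to 90000 nM.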

Compound 4, half-maximal inhibitory concentration: 53000 nM
Beside the measured number, compound 4's estimate is 2.1-fold (0.33 log units) below it; measured number inside the range.
By their numbers in this assay, from the lowest: compound 3; then compounds 2 and 4 (each within the scatter of the next). At a limit, above all of these: compound 1.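

In this assay, this carbon, para to a large group, is sensitive: fluoro in place of nitro gives a 15-fold higher number from compound 3 to compound 4 (1.18 log units; beyond the scatter), so keeping the second nitro group goes with the stronger inhibition here. Swapping 3,5-difluoro-2-nitrophenyl for 4,5-difluoro-2-nitrophenyl gives an at least 1.8-fold lower number from compound 1 to compound 4 (0.27 log units; that floor lies within the scatter), which does not separate the two compounds. The number for compound 1 is only a limit: the limit of > 100000 nM in this assay, at which 1 of the 4 values shown sits.

From the compounds shown here alone, whether an amine or a nitrile on this carbon would behave like nitro or like fluoro remains open. So does the true distance between compound 1 and compound 4.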